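The source may hold more compounds than are shown below. What is called first, only, known or untested is meant among the compounds shown, and "the series" means these compounds.

Working notes on a series built on one shared core, varied only in the group carried on a ring nitrogen. Compound 1 `C/C(=C\CC/C(C)=C/CC[C@@H]1[C@@]2(C)CCC(=O)C(C)(C)[C@H]2CC[C@@]1(C)O)CC/C=C(\C)C(=O)OCc1cn(-c2ccc(F)cc2)nn1` carries 4-fluorophenyl; in a functional assay on A549 cells (Homo sapiens) for antiproliferative activity, read by MTT assay, with a stated time of 48 h (on this read-out higher numbers stand for weaker inhibition and lower numbers for stronger inhibition), compound 1 gives > 150000 nM, which is a limit of the assay and not a number. Compound 2 `C/C(=C\CC/C(C)=C/CC[C@@H]1[C@@]2(C)CCC(=O)C(C)(C)[C@H]2CC[C@@]1(C)O)CC/C=C(\C)C(=O)OCc1cn(-c2ccc([N+](=O)[O-])cc2)nn1` carries 4-nitrophenyl; in this assay compound 2 gives > 150000 nM, again only a limit. Compound 3 `COc1ccc(-n2cc(COC(=O)/C(C)=C/CC/C(C)=C/CC/C(C)=C/CC[C@@H]3[C@@]4(C)CCC(=O)C(C)(C)[C@H]4CC[C@@]3(C)O)nn2)cc1` carries 4-methoxyphenyl; in this assay compound 3 gives > 150000 nM, also a limit. Compound 2 therefore stands exactly where the other two stand, since all three values sit at the limit of > 150000 nM in this assay, at which 3 of the 3 values shown sit. The steps a step that the two limits leave unreadable from compound 1 to compound 2, a step that the two limits leave unreadable from compound 1 to compound 3 and a step that the two limits leave unreadable from compound 2 to compound 3 are unreadable in size for that reason; none can be said to differ beyond the scatter.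

Compound 4 `C/C(=C\CC/C(C)=C/CC[C@@H]1[C@@]2(C)CCC(=O)C(C)(C)[C@H]2CC[C@@]1(C)O)CC/C=C(\C)C(=O)OCc1cn(-c2cccc(F)c2)nn1` is not yet measured; it differs from compound 2 by 3-fluorophenyl in place of 4-nitrophenyl on an aromatic nitrogen. The measured steps that bear on this change are the three changes of the group on the ring nitrogen, each unreadable because both ends sit at the limit of > 150000 nM in this assay, at which 3 of the 3 values shown sit. No change of that group has so far moved any compound off the limit, so no shift beyond the scatter is expected, and a number no higher from compound 2 to compound 4 (the limit leaves the size open) is expected to be about nothing. For compound 4 the estimate in this assay is 150000 nM, within 50000 nM to 500000 nM, most likely again reported only as a limit.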

Compound 4, half-maximal inhibitory concentration: 124000 nM
Compound 4: middle estimate off by 1.2-fold (0.08 log units), on the high side; the measured number falls inside the stated range.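

In this assay, for the compounds shown here, compound 4, with 3-fluorophenyl on the ring nitrogen, gives 124000 nM, the only value shown that is a number and not a limit. The change of group gives an at least 1.2-fold lower number from compound 2 to compound 4 (0.08 log units; that floor lies within the scatter), an at least 1.2-fold lower number from compound 3 to compound 4 (0.08 log units; that floor lies within the scatter) and an at least 1.2-fold lower number from compound 1 to compound 4 (0.08 log units; that floor lies within the scatter); each of these is a floor that lies within the scatter, so the change has not been shown to shift the read-out beyond the scatter, although the true sizes remain open. A measurable value can therefore occur with this group at this position, but the series still sits mostly at one place: the limit of > 150000 nM in this assay, at which 3 of the 4 values shown sit.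

The steps among compound 1, compound 2 and compound 3 cannot be read, and it remains open whether 3-fluorophenyl truly differs from 4-fluorophenyl or any other group shown. Also open, going by these compounds, is whether a different group on the ring nitrogen, such as an aminophenyl, a carboxylic acid on the phenyl ring or a longer alkyl chain, would give a value clearly beyond the scatter from that of compound 4.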